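Benzyl Substitution on the Indole Nitrogen of an Acrylic Acid

The compounds below may be only part of what the source reports. "The series", "measured", "known", "first", "only" and "open" are said of these compounds alone.

Compound 1 `CC(=O)n1cc(/C=C(/C(=O)O)c2ccc(Cl)cc2)c2cc(OCc3ccccc3)ccc21`: > 100000 nM
Compound 2 `O=C(O)/C(=C/c1c[nH]c2ccc(OCc3ccccc3)cc12)c1ccccc1`: "not determined" (no result reported)
Compound 3 `COc1ccc(/C(=C\c2c[nH]c3ccc(OCc4ccccc4)cc23)C(=O)O)cc1`: "not determined" (no result reported)

Three compounds have been looked at in a functional assay on LNCaP cells (Homo sapiens) for cytotoxicity, read by MTT assay, with a stated time of 72 h; on this read-out higher numbers stand for weaker inhibition and lower numbers for stronger inhibition. For compound 1 the value > 100000 nM is a limit of the assay and not a number, and it sits at the limit of > 100000 nM in this assay, at which 1 of the 3 values shown sits. Compound 2 has no result in this assay, and the same holds for compound 3. Compound 2 therefore stands without a number, beside one limit and one further entry without a number. Compound 4 `COc1ccc(Cn2cc(/C=C(/C(=O)O)c3ccccc3)c3cc(OCc4ccccc4)ccc32)cc1` differs from compound 2 by 4-methoxybenzyl in place of hydrogen on an aromatic nitrogen. Going by the values given here, with no measured step to draw on, the size and direction of the change in this assay cannot be judged from the data. Compound 4 is expected to give about 30000 nM, within 5000 nM to 100000 nM.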

Compound 4, half-maximal inhibitory concentration: 38200 nM
The estimate for compound 4 lay 1.3-fold (0.10 log units) below the measured number; the range from low to high includes it.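

Going by these compounds alone, no step from compound 2 to compound 4 can be read in this assay, where compound 2 has no number and compound 4 gives 38200 nM. From the compounds shown here alone, what 4-methoxybenzyl in place of hydrogen on the aromatic nitrogen changes remains open.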